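Methoxy for Fluoro on the Benzyl Ring

This account rests on a few compounds, and the source may have more. Where it says the series, first, only, none or still open, it means among the compounds named here.

Compound 1, `Nc1cc(N)c2nc(-c3ccccc3)c(NCc3ccc(Cl)c(Cl)c3)nc2c1`, is recorded in a functional assay on EKVX cells (Homo sapiens) for inhibition, read by sulforhodamine B assay, with a stated time of 48 h (on this read-out lower numbers stand for higher toxicity in this test and higher numbers for lower toxicity in this test), only as a limit of < 100000 nM. Among the compounds with values here, compound 2, `Nc1cc(N)c2nc(-c3ccccc3)c(NCc3ccc(F)cc3)nc2c1`, gives 8710 nM in this assay, the only number among the values shown. The step that the limit leaves unreadable from compound 1 to compound 2 cannot be read, since the limit of < 100000 nM in this assay, at which 1 of the 2 values shown sits, closes off one side of it. Compound 3, `COc1ccc(CNc2nc3cc(N)cc(N)c3nc2-c2ccccc2)cc1`, differs from compound 2 by methoxy in place of fluoro on an aromatic carbon of a six-membered aromatic ring of carbon only. Within the data shown here, no measured step bears on this exchange: the single step recorded is the unreadable one, so nothing shows how large a change on that ring tends to be. Compound 3 is therefore expected to stay within the scatter of compound 2, with an estimated step of a 1.0-fold higher number from compound 2 to compound 3 (0.01 log units; within the scatter). The estimate for compound 3 in this assay is 9000 nM, with a range from 3000 nM to 30000 nM.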

Compound 3, concentration lethal to 50% of the cells: 53700 nM
For compound 3 the middle estimate is 6.0-fold (0.78 log units) below the measured one; the measured number lies above the stated range.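

Going from the 4-fluorobenzyl to the 4-methoxybenzyl group in this assay gives a 6.2-fold higher number from compound 2 to compound 3 (0.79 log units; beyond the scatter), which lies beyond the scatter and points to lower toxicity in this test. Within the data shown here, this is the first readable step, and it shows that the group on this aromatic carbon, para to a large group, affects the read-out: exchanging one heavy atom for two is enough to move it. The value of compound 1 is only a limit, so neither step from compound 1 can be read: the limit of < 100000 nM in this assay, at which 1 of the 3 values shown sits.

As far as these compounds go, it remains open whether the shift follows the oxygen of the methoxy group or the larger size of the group. A hydroxy group, an ethyl group or an amine at the same place could tell these readings apart.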